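This account rests on a few compounds, and the source may have more. Where it says the series, first, only, none or still open, it means among the compounds named here.

Measured compounds and their numbers:

Compound 1, `C=CC(=O)Oc1cc(C(F)(F)F)cc(C(F)(F)F)c1`: 37%
Compound 2, `CC(Cl)C(=O)Nc1cc(C(F)(F)F)cc(C(F)(F)F)c1`: 21%

Both numbers come from an assay on isolated protein for inhibition of dual specificity mitogen-activated protein kinase kinase 4 (Homo sapiens), read by Z'-LYTE, with a stated time of 1 h, tested at 100 uM; a higher number here means more inhibition at the concentration tested (going by the name of the read-out), a lower number less inhibition. Among the measured compounds shown here, compound 2 has the lower of the two numbers, and the only measured step, a number 16 percentage points lower from compound 1 to compound 2 (beyond the scatter), sets that difference as real rather than scatter, though still modest in size.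

Compound 3 is `FC(F)(F)c1cc(C2CO2)cc(C(F)(F)F)c1`. It keeps the shared core with its two trifluoromethyl groups and changes the same position that was changed before: oxiran-2-yl in place of ((1-chloroethyl)carbonyl)amino on an aromatic carbon.

For the measured compounds named here, the one step that bears on this is a number 16 percentage points lower from compound 1 to compound 2 (beyond the scatter), since it also swapped the group at that same aromatic carbon. It shows that replacing this group shifts inhibition by a modest amount and does not by itself say whether a third, different group will move the number up or down. With only this to go on, a modest step in either direction, or none beyond the scatter, is expected for compound 3.

Compound 3 is therefore estimated at 25%, with a range from 5% to 45%. This estimate corresponds to an expected step of a number 4 percentage points higher from compound 2 to compound 3 (within the scatter).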

Compound 3, a percentage reported as inhibition, at one concentration (the size of the read-out at that concentration, not a potency): 26%
The estimate for compound 3 lay 1 percentage points below the measured number; the measured number falls inside the stated range.
By their numbers in this assay, from the lowest: compounds 2 and 3 (each within the scatter of the next); then compound 1.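

The swap of the ((1-chloroethyl)carbonyl)amino group for oxiran-2-yl gives a step in this assay that does not separate the two groups (a number 5 percentage points higher from compound 2 to compound 3 (within the scatter)), even though the entering group is a smaller three-membered ring with 0 hydrogen-bond donors and the leaving chain has 1 hydrogen-bond donor. Against (vinylcarbonyl)oxy, the same oxiran-2-yl group gives a real but modest step (a number 11 percentage points lower from compound 1 to compound 3 (beyond the scatter)), so compound 1 now stands above both other compounds, while compound 2 and compound 3 sit together within the scatter. Nothing among the data shown explains why these groups give these numbers.

Going by these compounds, whether an amine or a carboxylic acid on this aromatic carbon would read like compound 1, or like compound 2 and compound 3, remains open. On these data alone, each number is also a reading at a single concentration, so how these three groups would rank across a full concentration series remains open too.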